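A few compounds are considered here, and "the series" means these few. Any claim that something is new, unique, unknown or untested is made for them only; others in the source may bear on it.

Measured compounds in an ADME assay on MT2 cells (Homo sapiens) for cytotoxicity; on this read-out higher numbers stand for lower toxicity in this test and lower numbers for higher toxicity in this test:
compound 1 `COc1ccnc(Nc2ccc(Cl)c(OCC=C(C)C)c2)n1`, 9000 nM
compound 2 `CCOc1ccnc(Nc2ccc(Cl)c(OCC=C(C)C)c2)n1`, 19000 nM
compound 3 `COc1ccnc(Nc2ccc(C#N)c(OCC=C(C)C)c2)n1`, 230 nM

Compound 1 sits second highest of the three numbers: a 2.1-fold higher number from compound 1 to compound 2 (0.32 log units; beyond the scatter), whereas a 39-fold lower number from compound 1 to compound 3 (1.59 log units; beyond the scatter). Compound 4 `COc1ccnc(Nc2ccc(Cl)c(Oc3cccc(C)c3)c2)n1` is not yet measured. Compared with compound 1 the difference is: 3-methylphenyl in place of 3-methylbut-2-en-1-yl on an oxygen on an aromatic ring. Within the data shown here, no measured step swaps the (3-methylbut-2-en-1-yl)oxy group for 3-methylphenoxy. Among the measured compounds shown here, the only step touching that oxygen is a 2.1-fold higher number from compound 1 to compound 2 (0.32 log units; beyond the scatter), a modest one; the large step of a 39-fold lower number from compound 1 to compound 3 (1.59 log units; beyond the scatter) changes the chloro substituent instead and does not bear on this change. A small step, within or only just beyond the scatter, is therefore expected: a 1.3-fold lower number from compound 1 to compound 4 (0.11 log units; within the scatter). Compound 4 is accordingly estimated at 7000 nM, with a range from 2500 nM to 25000 nM.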

Compound 4, half-maximal cytotoxic concentration: 18000 nM
For compound 4 the middle estimate is 2.6-fold (0.41 log units) below the measured one; the range from low to high includes it.
By their numbers in this assay, from the lowest: compound 3; then compounds 1, 4 and 2 (each within the scatter of the next, the first and the last beyond it).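

In this assay, this oxygen on an aromatic ring takes 3-methylphenyl in place of 3-methylbut-2-en-1-yl with a 2.0-fold higher number from compound 1 to compound 4 (0.30 log units; within the scatter). Among these compounds, compounds 1, 2 and 3 all carry 3-methylbut-2-en-1-yl here, so this is the first reading of a change at this oxygen: an aromatic ring in place of an open chain leaves the number within the scatter. No available data explain this result.

Open, from the compounds shown here alone, is how a plain phenyl or a saturated butyl group on this oxygen would read. Also open, going by these compounds, is how 3-methylphenyl would read alongside cyano in place of chloro, the change behind a 39-fold lower number from compound 1 to compound 3 (1.59 log units; beyond the scatter).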